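Removing one fluoro from a difluorinated pentanol

The source may report more compounds than this note shows. Statements on the series, on what has been measured and on what is new or still open speak of the compounds shown alone.

Measured so far:
compound 1, `CCC(F)CCO`: 0.75
compound 2, `CCC(F)(F)CCO`: 0.92
compound 3, `OCCCC(F)(F)CF`: 0.58

In a physicochemical assay for lipophilicity, read by NMR (on this read-out higher numbers stand for higher lipophilicity and lower numbers for lower lipophilicity), compound 2 and compound 1 are related by a single change, (hydrogen in place of fluoro on a saturated chain carbon bound to a fluorine atom and two saturated chain carbons), and that change gave a number 0.17 log units lower from compound 2 to compound 1 (within the scatter). Compound 3 has the lowest of the three numbers; its values against compound 1 lie within the scatter, against compound 2 beyond it. The difference between the cores of compound 2 and compound 3 is not broken down here. Compound 4, `OCCCC(F)CF`, is not yet measured; it differs from compound 3 by hydrogen in place of fluoro on a saturated chain carbon bound to a fluorine atom and two saturated chain carbons, the same change as before, at a place described in the same words. On that basis the step expected in this assay is a number 0.17 log units lower from compound 3 to compound 4 (within the scatter), matching a number 0.17 log units lower from compound 2 to compound 1 (within the scatter). For compound 4 the estimate is 0.41, expected between 0.15 and 0.7.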

Compound 4, partition coefficient: 0.11
Compound 4: the middle estimate sits 0.30 log units above what was measured; the measured number lies below the stated range.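

In this assay the same replacement of fluoro by hydrogen gave a number 0.47 log units lower from compound 3 to compound 4 (beyond the scatter) and, on the other core, a number 0.17 log units lower from compound 2 to compound 1 (within the scatter). For the compounds shown here, both steps run in the same direction, but only the one on the core of compound 3 lies beyond the scatter, so the size of the step did not carry over from one core to the other. This rests on a single pair for each core and sets no rule for the series, and nothing at hand bears on why the two steps differ.

The compounds shown leave open how the same replacement behaves on a longer chain, or in compounds carrying an amine or a carboxylic acid. They also leave open which step size, if either, would hold on a third core.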